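Working notes: dithiocarbamate acetamides, cytotoxicity on a liver line

A few compounds are considered here, and "the series" means these few. Any claim that something is new, unique, unknown or untested is made for them only; others in the source may bear on it.

Measured in a functional assay on SMMC-7721 cells (Homo sapiens) for cytotoxicity, read by MTT assay, with a stated time of 72 h; on this read-out lower numbers stand for stronger inhibition and higher numbers for weaker inhibition:
- compound 1 : `CCOC(=O)c1ccc(NC(=O)CSC(=S)N[C@H]2CCOC2=O)cc1`, giving 64900 nM
- compound 2 : `O=C(CCl)Nc1ccc(C(=O)/C=C/c2ccc(Br)cc2)cc1`, giving 13300 nM
- compound 3 : `O=C(CSC(=S)N[C@H]1CCOC1=O)Nc1ccc(C(=O)/C=C/c2ccc(Cl)cc2)cc1`; for compound 3 the read-out is a limit of the assay, > 128000 nM

Compound 3 therefore stands at the limit of this assay, the point (the limit of > 128000 nM in this assay, at which 1 of the 3 values shown sits). Going by the values given here, of the values shown, compound 3 is the only one that sits there; compound 1 and compound 2 each give a number, and no single-site step connects compound 2 to either of the others, so for that pair only the two values themselves can be read.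

The next compound, compound 4, is `O=C(CSC(=S)N[C@H]1CCOC1=O)Nc1ccc(C(=O)/C=C/c2ccc(Br)cc2)cc1`, not yet measured in this assay. It differs from compound 3 as follows: bromo in place of chloro on an aromatic carbon.

Among the compounds with values here, the only measured single-site step is an at least 1.9-fold higher number from compound 1 to compound 3 (0.29 log units; that floor lies within the scatter), a change at a different position and one that ends at the limit. Within the data shown here, no measured step in this assay exchanges a halogen on the phenyl ring, so nothing recorded here bears directly on bromo in place of chloro. The expectation is a step from compound 3 to compound 4 of a step that the limit leaves unreadable from compound 3 to compound 4, that is, none beyond the scatter. Compound 4 is estimated at 130000 nM, with a range from 50000 nM to 350000 nM, and a real chance that this assay again reports only a limit.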

Compound 4, half-maximal inhibitory concentration: 18000 nM
The estimate for compound 4 lay 7.2-fold (0.86 log units) above the measured number; measured number below the stated range.
By their numbers in this assay, from the lowest: compounds 2 and 4 (each within the scatter of the next); then compound 1. At a limit, above all of these: compound 3.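

In this assay, going by these compounds alone, the first measured change at this aromatic carbon, 4-chlorophenyl to 4-bromophenyl on the shared core, gives an at least 7.1-fold lower number from compound 3 to compound 4 (0.85 log units; beyond the scatter), so a single halogen exchange separates a measurable value from one that is not. Compound 3 stands at a limit of the assay and not at a number, so this step is a floor and its full size cannot be read: the limit of > 128000 nM in this assay, at which 1 of the 4 values shown sits.

The halogen also changes how the replacement of ethoxy reads: with the 2-(4-bromophenyl)ethenyl group the result is a 3.6-fold lower number from compound 1 to compound 4 (0.56 log units; beyond the scatter), a measured step that does not end at a limit, while exchanging the chlorine atom on the saturated chain carbon for the larger group gives a 1.4-fold higher number from compound 2 to compound 4 (0.13 log units; within the scatter).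

Only chloro and bromo are shown on this aromatic carbon, so it stays open whether fluoro, iodo, methoxy or a nitrile would read like bromo or like chloro. From the compounds shown here alone, it also stays open whether the chloro-to-bromo exchange has a comparable effect in the chloroacetamide form represented by compound 2.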